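Swapping the heteroaryl on the sulfonamide nitrogen of compound 2

The source may hold more compounds than are shown below. What is called first, only, known or untested is meant among the compounds shown, and "the series" means these compounds.

Measured so far in a functional assay on B16-F10 cells (Mus musculus) for cytotoxicity, read by CCK-8 assay, with a stated time of 48 h; on this read-out higher numbers stand for weaker inhibition and lower numbers for stronger inhibition:
compound 1 `NS(=O)(=O)c1ccc(/N=C/c2c(Cl)c3ccccc3oc2=O)cc1`: 300 nM
compound 2 `Cc1cc(C)nc(NS(=O)(=O)c2ccc(/N=C/c3c(Cl)c4ccccc4oc3=O)cc2)n1`: 170 nM

Compound 2 and compound 1 sit within the scatter of each other, so neither can be called the stronger. Compound 3 `Cc1cc(NS(=O)(=O)c2ccc(/N=C/c3c(Cl)c4ccccc4oc3=O)cc2)no1` carries 5-methyl-1,2-oxazol-3-yl in place of 4,6-dimethylpyrimidin-2-yl on a sulfonamide nitrogen. Going by the values given here, the only step that bears on this position is a 1.8-fold lower number from compound 1 to compound 2 (0.25 log units; within the scatter), where even removing the whole ring in favour of hydrogen moved the number within the scatter only. A change from one small heteroaryl to another at that nitrogen is therefore expected to give no step beyond the scatter, a 1.2-fold higher number from compound 2 to compound 3 (0.07 log units; within the scatter). Compound 3 is estimated at 200 nM, within 80 nM to 500 nM.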

Compound 3, half-maximal inhibitory concentration: 270 nM
Estimate against measurement, compound 3: 1.4-fold (0.13 log units) below, within the range that was stated.
By their numbers in this assay, from the lowest: compounds 2, 3 and 1 (each within the scatter of the next).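

In this assay, 5-methyl-1,2-oxazol-3-yl in place of 4,6-dimethylpyrimidin-2-yl on the sulfonamide nitrogen gave a 1.6-fold higher number from compound 2 to compound 3 (0.20 log units; within the scatter), and the same group in place of hydrogen gave a 1.1-fold lower number from compound 1 to compound 3 (0.05 log units; within the scatter). A five-membered aromatic ring there thus behaves like the six-membered one, and no step among these three groups on this nitrogen lies beyond the scatter. Nothing at hand offers an explanation for this.

Going by these compounds, it remains open whether a group of another kind on that nitrogen, such as a longer chain ending in an amine or a carboxylic acid, would move the number beyond the scatter.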